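Tetrazole regioisomers on the alkoxy chain terminus

A few compounds are considered here, and "the series" means these few. Any claim that something is new, unique, unknown or untested is made for them only; others in the source may bear on it.

Of the compounds shown here, three sharing one core have been measured so far in an assay on isolated protein for binding affinity to leukotriene B4 receptor (Homo sapiens), tested at 0.1 uM; on this read-out lower numbers stand for less inhibition and higher numbers for more inhibition at the one concentration tested (going by the name of the read-out). Compound 1 `CCc1cc(C(C)=O)c(O)cc1OCCCCCC(C)(C)C#N` gives 17%. Compound 2 `CCc1cc(C(C)=O)c(O)cc1OCCCCCCC(C)(C)c1nnn[nH]1` gives 13% in this assay, and compound 3 `CCc1cc(C(C)=O)c(O)cc1OCCCCCC(C)(C)c1nnnn1C` gives 14%. Among these three numbers compound 3 stands second highest; its nearest neighbour is compound 2, with a number 1 percentage points higher from compound 2 to compound 3 (within the scatter), and its furthest is compound 1, with a number 3 percentage points lower from compound 1 to compound 3 (within the scatter). The remaining pair shows a number 4 percentage points lower from compound 1 to compound 2 (within the scatter). None of the three steps leaves the scatter.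

Compound 4 `CCc1cc(C(C)=O)c(O)cc1OCCCCCC(C)(C)c1nnn(C)n1` is not yet measured. It differs from compound 3 as follows: 2-methyl-2H-tetrazol-5-yl in place of 1-methyl-1H-tetrazol-5-yl on a saturated chain carbon bound to three saturated chain carbons. Among the compounds with values here, the steps that bear on this change are those exchanging the terminal group on the same chain, from compound 1 to compound 3 and from compound 2 to compound 3, both within the scatter. The expected step in this assay is therefore no change at the digits printed from compound 3 to compound 4 (within the scatter), no clear direction. Compound 4 is estimated at 14%, with a range from 4% to 25%.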

Compound 4, a percentage reported as inhibition, at one concentration (the size of the read-out at that concentration, not a potency): 16%
For compound 4 the middle estimate is 2 percentage points below the measured one; measured number inside the range.
By their numbers in this assay, from the lowest: compounds 2, 3, 4 and 1 (each within the scatter of the next).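

Exchanging 1-methyl-1H-tetrazol-5-yl for its isomer 2-methyl-2H-tetrazol-5-yl on a saturated chain carbon bound to three saturated chain carbons gives in this assay a result of a number 2 percentage points higher from compound 3 to compound 4 (within the scatter) and so does not separate the two methyl tetrazole isomers on this read-out. The same holds against the other terminal groups, with a number 3 percentage points higher from compound 2 to compound 4 (within the scatter) and a number 1 percentage points lower from compound 1 to compound 4 (within the scatter) in the same read-out, so the nitrile and all three tetrazole compounds remain indistinguishable here. No measurement is available that accounts for these numbers.

Still open, as far as these compounds go, is whether any terminal group at this place can move the read-out beyond the scatter, for example a carboxylic acid or a primary amide. A longer chain carrying 2-methyl-2H-tetrazol-5-yl would show whether chain length matters for this isomer.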